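The source may report more compounds than this note shows. Statements on the series, on what has been measured and on what is new or still open speak of the compounds shown alone.

Measured so far in an ADME assay on A549 cells (Homo sapiens) for cytotoxicity, read by CellTiter-Glo; a higher number here means that more compound is tolerated, a lower number that less compound is tolerated:
compound 1 `Cc1c(Cc2ccc(F)cc2)c(=O)oc2cc(OCC(O)CN3CCC(C(N)=O)CC3)ccc12`: compound 1 gives 89300 nM.
compound 2 `Cc1cc(F)ccc1Cc1c(C)c2ccc(OCC(O)CN3CCC(C(N)=O)CC3)cc2oc1=O`: compound 2 gives > 100000 nM, which is a limit of the assay and not a number.
compound 3 `COC(=O)c1ccc(Cc2c(C)c3ccc(OCC(O)CN4CCC(C(N)=O)CC4)cc3oc2=O)cc1`: compound 3 gives > 100000 nM, again a limit of the assay.

Compound 3 thus stands only at a limit in this assay, and compound 2 stands at the same limit, so the limit of > 100000 nM in this assay, at which 2 of the 3 values shown sit, fixes where two of the three values sit and only compound 1 yields a number. Both measured steps that start from a number, an at least 1.1-fold higher number from compound 1 to compound 2 (0.04 log units; that floor lies within the scatter) and an at least 1.1-fold higher number from compound 1 to compound 3 (0.04 log units; that floor lies within the scatter), end at that limit. The remaining step, a step that the two limits leave unreadable from compound 2 to compound 3, joins two limits.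

Compound 4 `Cc1c(Cc2ccc(-c3ccc(Cl)cc3)cc2)c(=O)oc2cc(OCC(O)CN3CCC(C(N)=O)CC3)ccc12` differs from compound 3 by 4-chlorophenyl in place of methoxycarbonyl on an aromatic carbon. Going by the values given here, no measured step exchanges a methoxycarbonyl for a 4-chlorophenyl, so none bears on it directly, and the readable steps stay within the scatter. The number expected for compound 4 in this assay lies near the top of the measured range, with a real chance that only a limit is returned again. The step estimated here is an at least 1.6-fold lower number from compound 3 to compound 4 (0.22 log units; that floor lies within the scatter). The estimated value for compound 4 is 60000 nM, expected between 20000 nM and 100000 nM.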

Compound 4, half-maximal cytotoxic concentration: 32900 nM
Estimate against measurement, compound 4: 1.8-fold (0.26 log units) above; the measured number falls inside the stated range.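

In this assay, the aromatic carbon para to a large group now proves responsive to its substituent: 4-chlorophenyl there gives an at least 3.0-fold lower number from compound 3 to compound 4 (0.48 log units; beyond the scatter) and a 2.7-fold lower number from compound 1 to compound 4 (0.43 log units; beyond the scatter), both beyond the scatter. The earlier readable steps at this part of the series, from compound 1 to compound 2 and to compound 3, gave only floors within the scatter, so no change beyond it had been seen. Compound 3 stands at a limit and not at a number, so the step from it is only a floor: the limit of > 100000 nM in this assay, at which 2 of the 4 values shown sit.

From the compounds shown here alone, whether the ring of 4-chlorophenyl or its chlorine carries the step stays open, and a plain phenyl would separate the two. Going by these compounds, how an amine or a carboxylic acid at this position would read in this assay also stays open.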